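From 4-chlorobenzyl to methyl: cytotoxicity notes on the core

The source may report more compounds than this note shows. Statements on the series, on what has been measured and on what is new or still open speak of the compounds shown alone.

Measured so far:
compound 1 `CC(=O)Oc1ccc2c(c1)C(C)=CC(C)(C)N2Cc1ccc(Cl)cc1`, 22000 nM
compound 2 `CC(=O)Oc1ccc2c(c1)C(C)=CC(C)(C)N2Cc1ccc(C(F)(F)F)cc1`, 14000 nM
compound 3 `COc1cc(OC)cc(C(=O)Oc2ccc3c(c2)C(C)=CC(C)(C)N3Cc2ccc(Cl)cc2)c1`, a limit only: > 190000 nM

In an ADME assay on L6 cells (Rattus norvegicus) for cytotoxicity, read by resazurin assay, with a stated time of 70 h (a lower number here means a stronger inhibitor, a higher number a weaker inhibitor), compound 1 gives 22000 nM, the highest of the two numbers shown. Compound 2 is nearest, and the step of a 1.6-fold lower number from compound 1 to compound 2 (0.20 log units; within the scatter) lies within the scatter. Compound 3 reached only the assay limit (the limit of > 190000 nM in this assay, at which 1 of the 3 values shown sits); the step of an at least 8.6-fold higher number from compound 1 to compound 3 (0.93 log units; beyond the scatter) is beyond the scatter.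

Compound 4 `CC(=O)Oc1ccc2c(c1)C(C)=CC(C)(C)N2C` has not been measured in this assay. It differs from compound 1 by hydrogen in place of 4-chlorophenyl on a saturated chain carbon bound to a nitrogen on an aromatic ring in a ring. Neither measured step is the same change: the step from compound 1 to compound 2 alters only the substituent on the ring that is now removed, and the step from compound 1 to compound 3 enlarges the ester rather than shrinking the group on the ring nitrogen. For the measured compounds named here, the one step beyond the scatter, from compound 1 to compound 3, went toward a higher number on adding bulk, and removing the 4-chlorophenyl is a change of comparable size in the other sense, so a shift in either direction is possible, with the wider range on the higher side. Compound 4 is estimated at 45000 nM, between 12000 nM and 190000 nM; the expected step is a 2.0-fold higher number from compound 1 to compound 4 (0.31 log units; beyond the scatter).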

Compound 4, half-maximal inhibitory concentration: 41000 nM
Compound 4: middle estimate off by 1.1-fold (0.04 log units), on the high side; the measured number falls inside the stated range.
By their numbers in this assay, from the lowest: compounds 2, 1 and 4 (each within the scatter of the next, the first and the last beyond it). At a limit, above all of these: compound 3.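

Cutting 4-chlorobenzyl down to methyl is the first change shown that removes the whole 4-chlorophenyl rather than a substituent on it, and in this assay it gives a 1.9-fold higher number from compound 1 to compound 4 (0.27 log units; within the scatter) without leaving the usual scatter. The earlier step between chloro and trifluoromethyl covered only exchange on that aromatic ring, whereas this result shows that, for this pair, the read-out stays within the scatter even with the ring gone, so the 4-chlorophenyl is not needed to hold the number at this level. The only step shown beyond the scatter remains the one at the ester, an at least 8.6-fold higher number from compound 1 to compound 3 (0.93 log units; beyond the scatter), and nothing measured here gives a cause for the step to compound 4.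

As far as these compounds go, whether a longer chain in place of methyl, or an amine or a carboxylic acid on the benzyl ring, would move the number beyond the scatter stays open. Also open, from the compounds shown here alone, is whether the 3,5-dimethoxyphenyl in place of methyl on the carbonyl carbon would have the same outcome on the core of compound 4 as on the core of compound 1.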